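Swapping the aryl urea substitution pattern across two cores

A few compounds are considered here, and "the series" means these few. Any claim that something is new, unique, unknown or untested is made for them only; others in the source may bear on it.

Three diaryl ureas have been tested in a functional assay on A-375 cells (Homo sapiens) for inhibition, read by MTT assay, with a stated time of 120 h; a lower number here means a stronger inhibitor, a higher number a weaker inhibitor. Compound 1 `CC(NC(=O)/C=C/c1ccc(NC(=O)Nc2ccc(Cl)c(C(F)(F)F)c2)cc1)c1ccccc1` gives 20800 nM, compound 3 `CC(NC(=O)/C=C/c1ccc(NC(=O)Nc2cc(C(F)(F)F)ccc2Cl)cc1)c1ccccc1` gives 40900 nM, and compound 2 `CC(NC(=O)c1ccc(-c2ccc(NC(=O)Nc3cc(C(F)(F)F)ccc3Cl)cc2)cc1)c1ccccc1` gives 16900 nM. Compounds 1 and 3 share one core and differ only in the aryl group on the urea: 4-chloro-3-(trifluoromethyl)phenyl in place of 2-chloro-5-(trifluoromethyl)phenyl on an amide-type nitrogen. This change gave a 2.0-fold lower number from compound 3 to compound 1 (0.29 log units; within the scatter). Compound 2 carries a different core; the difference between the two cores is not broken down here. Compound 2 and compound 1 lie within the scatter of each other, while compound 2 gives a lower number than compound 3 by a margin beyond the scatter.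

Compound 4 `CC(NC(=O)c1ccc(-c2ccc(NC(=O)Nc3ccc(Cl)c(C(F)(F)F)c3)cc2)cc1)c1ccccc1` has not yet been measured. It stands to compound 2 as compound 1 stands to compound 3: 4-chloro-3-(trifluoromethyl)phenyl in place of 2-chloro-5-(trifluoromethyl)phenyl on an amide-type nitrogen. The place of the change is described in the same words in both pairs, so the change is the same one made on the other core.

Among the measured compounds shown here, the only guide to its effect is the step from compound 3 to compound 1, which was small and within the scatter. For the measured compounds named here, compound 4 is therefore expected to give a number in this assay not far from that of compound 2, with an estimated step of a 1.7-fold lower number from compound 2 to compound 4 (0.23 log units; within the scatter), resting on the single earlier step of a 2.0-fold lower number from compound 3 to compound 1 (0.29 log units; within the scatter) as its precedent. For compound 4 the estimate in this assay is 10000 nM, with a range from 4000 nM to 25000 nM allowing for the possibility that the change behaves differently on this core.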

Compound 4, half-maximal inhibitory concentration: 12800 nM
Estimate against measurement, compound 4: 1.3-fold (0.11 log units) below; measured number inside the range.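

In this assay, placing 4-chloro-3-(trifluoromethyl)phenyl where 2-chloro-5-(trifluoromethyl)phenyl stood on an amide-type nitrogen gave a 1.3-fold lower number from compound 2 to compound 4 (0.12 log units; within the scatter) on the core of compound 2, and this step is small enough to be no firm effect on its own. Set beside the step already seen on the core of compound 1, it shows no sign that the core alters what the swap does: the same change on two cores in this assay, a 2.0-fold lower number (0.29 log units; within the scatter) from compound 3 to compound 1 and a 1.3-fold lower number (0.12 log units; within the scatter) from compound 2 to compound 4, 1.5-fold (0.17 log units) apart, within the scatter of two such steps. The two cores are therefore consistent with a change that carries over unaltered, but each step lies within the scatter, so the data do not show that the swap has a real effect on either core, nor that the two steps truly match rather than merely being too small to tell apart, and two pairs of compounds set no rule for the series.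

The compounds shown leave open what happens when the aryl group on the urea carries something other than chlorine and trifluoromethyl, such as a nitrile or a methoxy group, and whether a larger step would then appear and hold across both cores. They also leave open how far the difference in the cores themselves contributes, and whether a carboxylic acid or an amine on the far end of either core would change the picture.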